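The source may report more compounds than this note shows. Statements on the series, on what has been measured and on what is new or still open speak of the compounds shown alone.

Compound 1 `O=C1CCC(O)(c2cccc(C(F)(F)F)c2)N1`: > 200 mg/kg, a limit
Compound 2 `CN(C)C(=O)CCC(=O)c1cccc(C(F)(F)F)c1`: > 37.5 mg/kg, a limit

The read-out is a functional assay on the whole organism with Mus musculus as the target; on this read-out lower numbers stand for an effect already at smaller amounts and higher numbers for an effect only at larger amounts of compound. Compound 2 has no number here, only the limit > 37.5 mg/kg. Compound 1 also has only a limit, > 200 mg/kg. Going by the values given here, the two limits define no measured step, so the series gives no size for any structural change.

Compound 3 `CC(C)NC(=O)CCC(=O)c1cccc(C(F)(F)F)c1` has isopropylamino in place of dimethylamino on a carbonyl carbon. Among the compounds with values here, with no measured step as a guide, no shift beyond the scatter is expected in this assay, and no direction can be firmly assigned. The expected step is a step that the limit leaves unreadable from compound 2 to compound 3, and this estimate rests only on the limit of compound 2, > 37.5 mg/kg. A reported limit is as likely as a number. For compound 3 the estimated value is 60 mg/kg, with an expected range of 20 mg/kg to 200 mg/kg.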

Compound 3, dose for half-maximal effect: > 150 mg/kg
Compound 3: a limit, no number (the forecaster's own chance of this, stated with the estimate: 45%); middle value at least 2.5-fold (0.39 log units) from the limit.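

In this assay compound 3 gives > 150 mg/kg, a limit. Going by these compounds alone, compound 2 gives > 37.5 mg/kg, also a limit, so no step between compound 2 and compound 3 can be read. The compounds shown leave open whether isopropylamino in place of dimethylamino on a carbonyl carbon shifts the dose for half-maximal effect at all, and in which direction.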